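The source may report more compounds than this note shows. Statements on the series, on what has been measured and on what is new or still open speak of the compounds shown alone.

In a functional assay on PC-12 cells (Rattus norvegicus) for cytotoxicity, read by MTT assay, with stated times of 2 h and 24 h, tested at 5 uM (on this read-out lower numbers stand for a weaker effect and higher numbers for a stronger effect at the one concentration tested), compound 3, `Oc1cc(C(F)(F)F)ccc1-c1nc(-c2ccccc2O)n(-c2ccc(C(F)(F)F)cc2)n1`, gives 90.5%. For the measured compounds named here, of the three compounds measured so far this is the lowest number, yet every gap around it stays within the scatter: compound 2, `Oc1cc(C(F)(F)F)ccc1-c1nc(-c2ccccc2O)n(-c2ccc(I)cc2)n1`, gives 94.4% and compound 1, `CC(C)c1ccc(-n2nc(-c3ccc(C(F)(F)F)cc3O)nc2-c2ccccc2O)cc1`, gives 100%. The three measured steps each change only the group on the aromatic carbon para to a large group, and none of them leaves the scatter: a number 5.6 percentage points lower from compound 1 to compound 2 (within the scatter), a number 9.5 percentage points lower from compound 1 to compound 3 (within the scatter) and a number 3.9 percentage points lower from compound 2 to compound 3 (within the scatter).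

Compound 4, `COc1ccc(-n2nc(-c3ccc(C(F)(F)F)cc3O)nc2-c2ccccc2O)cc1`, differs from compound 3 at the same position, with methoxy in place of trifluoromethyl on an aromatic carbon. Going by the values given here, no measured step involves methoxy, so the bearing of the known steps is indirect; they show only that three different groups at this position gave numbers indistinguishable within the scatter. On that basis compound 4 is expected to show no step beyond the scatter, and the expected step is a number 1.5 percentage points higher from compound 3 to compound 4 (within the scatter). Compound 4 is therefore estimated at 92%, with a range from 78% to 100%.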

Compound 4, a percentage reported as activity, at one concentration (the size of the read-out at that concentration, not a potency): 86.6%
Compound 4: middle estimate off by 5.4 percentage points, on the high side, and the stated range covers the measured number.
By their numbers in this assay, from the lowest: compounds 4, 3, 2 and 1 (each within the scatter of the next, the first and the last beyond it).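

In this assay, for the compounds shown here, methoxy is the first group at this position to open a gap beyond the scatter, and it does so only against isopropyl, in a number 13.4 percentage points lower from compound 1 to compound 4 (beyond the scatter) and in no other step. Both a number 3.9 percentage points lower from compound 3 to compound 4 (within the scatter) and a number 7.8 percentage points lower from compound 2 to compound 4 (within the scatter) stay inside the scatter, so among these four groups only the two ends of the series, compound 1 and compound 4, can be told apart. Nothing available explains the gap between isopropyl and methoxy.

The compounds shown leave open how an amine or a carboxylic acid would read at this position, and whether a chain longer than isopropyl would stay near compound 1. As far as these compounds go, they carry no change elsewhere on the shared core, so whether the same step would hold in another setting remains unknown.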